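A few compounds are considered here, and "the series" means these few. Any claim that something is new, unique, unknown or untested is made for them only; others in the source may bear on it.

Working notes on the series.

Three compounds have a number in a functional assay on HEK293 cells for agonist activity at D(4) dopamine receptor (Homo sapiens), read by FLIPR; a lower number here means that less compound is needed, a higher number that more compound is needed for the effect. Compound 1 `Cc1cc(C)cc(NC(=O)CN2CCC(c3cccc[n+]3[O-])CC2)c1` gives 52 nM, the highest of the three. Compound 2 `Cc1cccc(NC(=O)CN2CCC(c3cccc(O)c3)CC2)c1` gives 8 nM, and compound 3 `Cc1cccc(NC(=O)CN2CCC(c3ccccc3F)CC2)c1` gives 1 nM. Within the data shown here, the only single-point step among them is an 8.0-fold lower number from compound 2 to compound 3 (0.90 log units; beyond the scatter), a change on the saturated ring rather than on the amide. Compound 1 differs from compound 2 and from compound 3 in two places at once, so its gap to them cannot be assigned to either site.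

Compound 4 `O=C(CN1CCC(c2cccc[n+]2[O-])CC1)Nc1ccc(F)cc1` is the next entry, to be measured in this assay. It differs from compound 1 by 4-fluorophenyl in place of 3,5-dimethylphenyl on an amide-type nitrogen. Among the measured compounds shown here, no measured step touches the amide-side aryl group; the one step in hand concerns the other ring and gives no guide to this change. The expectation for compound 4 therefore leans on the number of compound 1 alone, with a wide range: the number is estimated to stay close to that of compound 1, the step of a 1.5-fold higher number from compound 1 to compound 4 (0.19 log units; within the scatter) being an estimate and not a measurement. Compound 4 is expected to give about 80 nM, between 20 nM and 400 nM.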

Compound 4, half-maximal effective concentration: 85 nM
Compound 4: the middle estimate sits 1.1-fold (0.03 log units) below what was measured; the range from low to high includes it.
By their numbers in this assay, from the lowest: compound 3; then compound 2; then compounds 1 and 4 (each within the scatter of the next).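

In this assay, among these compounds, the replacement on the amide-type nitrogen gives a 1.6-fold higher number from compound 1 to compound 4 (0.21 log units; within the scatter), the first measured step at this position, and it lies within the scatter. Among the compounds shown here, on the core of compound 1, 4-fluorophenyl and 3,5-dimethylphenyl therefore cannot be told apart in this read-out, whereas the one earlier step, which concerned the other ring, lay beyond the scatter. No measurement at hand speaks to why these two aryl groups read alike.

This single pair does not show whether the same replacement would also read within the scatter on the cores of compound 2 and compound 3, which carry other groups on the saturated ring and a different aryl group on the amide, so the steps that would link them to compound 1 or compound 4 cannot be read. It also leaves open how far this position tolerates other groups, such as a phenyl ring bearing an amine or a carboxylic acid, or a longer alkyl chain in place of the aryl group.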